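This account rests on a few compounds, and the source may have more. Where it says the series, first, only, none or still open, it means among the compounds named here.

In an ADME assay on RAW264.7 cells (Mus musculus) for cytotoxicity, read by MTT assay (a higher number here means a weaker inhibitor, a lower number a stronger inhibitor), compound 1 (`CCCCCCCCCCOc1cccc(O)c1C(=O)/C=C/c1cc(OC)c(O)c(OC)c1`) gives > 30000 nM as a limit of the assay and not a number. Compound 2 (`CCCCCCCCCCOc1cccc(O)c1C(=O)/C=C/c1ccccc1O`) gives > 30000 nM as a limit too. Compound 2 thus has no number of its own, only the limit of > 30000 nM in this assay, at which 2 of the 2 values shown sit, to place it.

Compound 3 (`CCCCCCCCCCOc1cccc(O)c1C(=O)/C=C/c1ccc(Cl)c(Cl)c1`) differs from compound 2 in one place, by 3,4-dichlorophenyl in place of 2-hydroxyphenyl on a double-bonded chain carbon bound to a double-bonded chain carbon in all: 3,4-dichlorophenyl in place of 2-hydroxyphenyl, on a double-bonded chain carbon bound to a double-bonded chain carbon. Among the measured compounds shown here, the only measured change at that place is a step that the two limits leave unreadable from compound 1 to compound 2 and so offers no size to carry over. No step beyond the usual scatter is therefore expected in this assay, and no direction can be argued, so the estimated a number no higher from compound 2 to compound 3 (the limit leaves the size open) stays small. For compound 3 the estimated value is 30000 nM with an expected range of 12000 nM to 60000 nM in this measurement.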

Compound 3, half-maximal inhibitory concentration: > 30000 nM
Compound 3 gave a limit, no number (the forecaster's own chance of this, stated with the estimate: 60%); the middle value lies on the limit itself.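

No step can be read among compound 1, compound 2 and compound 3, since each gives a limit of the assay and not a number: the limit of > 30000 nM in this assay, at which 3 of the 3 values shown sit. The compounds shown leave open whether swapping these aromatic groups changes the result in this assay at all, and by how much.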